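Hydroxy to Aminomethyl on a Spiro Scaffold: Two Cores Compared

The source may hold more compounds than are shown below. What is called first, only, known or untested is meant among the compounds shown, and "the series" means these compounds.

The measured compounds are:
compound 1, `CC(C)(C)c1ccc(C(=O)N2CCC3(CC2)C(=O)N(CC(=O)NCCO)CN3c2ccccc2)cc1`, with 1000 nM in an assay on HEK293 cells for displacement of a labelled ligand from NPC1-like intracellular cholesterol transporter 1 (Homo sapiens); a higher number here means a weaker inhibitor, a lower number a stronger inhibitor;
compound 2, `CC(C)(C)c1ccc(C(=O)N2CCC3(CC2)C(=O)N(CC(=O)NCCCN)CN3c2ccccc2)cc1`, with 4200 nM in this assay;
compound 3, `O=C(CN1CN(c2ccccc2)C2(CCN(C(=O)c3ccc(C4CCCCC4)cc3)CC2)C1=O)NCO`, with 8300 nM in this assay.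

Compounds 1 and 2 share one core and differ only at the end of the side chain: aminomethyl in place of hydroxy on a saturated chain carbon, two bonds along the chain from an amide-type nitrogen. This change gave a 4.2-fold higher number from compound 1 to compound 2 (0.62 log units; beyond the scatter). Compound 3 carries a different core; the difference between the two cores is not broken down here. Compound 3 has the highest number of the three, and against compound 2 the gap lies within the scatter, while against compound 1 it lies beyond it.

Compound 4, `NCCNC(=O)CN1CN(c2ccccc2)C2(CCN(C(=O)c3ccc(C4CCCCC4)cc3)CC2)C1=O`, has not yet been measured. It differs from compound 3 as follows: aminomethyl in place of hydroxy on a saturated chain carbon bound to an amide-type nitrogen. This is the same kind of change as that from compound 1 to compound 2, but not the same: in one case the carbon is two bonds along the chain from an amide-type nitrogen, in the other it is bound to an amide-type nitrogen. For the measured compounds named here, the expectation for compound 4 rests on the one measured instance of this kind of change, and on compound 3, whose value is 8300 nM, so a weakening of about the same size is expected, a 2.7-fold higher number from compound 3 to compound 4 (0.42 log units; beyond the scatter). Compound 4 is therefore estimated at 22000 nM in this assay, with a range from 7000 nM to 60000 nM.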

Compound 4, half-maximal inhibitory concentration: 3800 nM
Estimate against measurement, compound 4: 5.8-fold (0.76 log units) above; the measured number lies below the stated range.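

In this assay, aminomethyl in place of hydroxy on a saturated chain carbon bound to an amide-type nitrogen gave a 2.2-fold lower number from compound 3 to compound 4 (0.34 log units; beyond the scatter). Set beside the earlier step, this shows that the effect of the change did not carry over from one core to the other, and that its direction reversed: the same change on two cores in this assay, a 4.2-fold higher number (0.62 log units; beyond the scatter) from compound 1 to compound 2 and a 2.2-fold lower number (0.34 log units; beyond the scatter) from compound 3 to compound 4, 9.2-fold (0.96 log units) apart, beyond the scatter of two such steps

This does not show that the core alone decides the outcome, for the two pairs also differ in where the change sits: two bonds along the chain from an amide-type nitrogen in compounds 1 and 2, and on a carbon bound to an amide-type nitrogen in compounds 3 and 4. With a single pair on each core, the contributions of core and chain position cannot be separated, and two pairs establish no rule for the series.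

The compounds shown leave open how the core of compound 3 would respond to the same swap made two bonds along the chain from the amide-type nitrogen, and how the core of compound 1 would respond to it on a carbon bound to that nitrogen. They also leave open whether a carboxylic acid or a longer chain ending in an amine at this end of the side chain would follow compound 2 or compound 4.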